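The compounds below may be only part of what the source reports. "The series", "measured", "known", "first", "only" and "open" are said of these compounds alone.

In a functional assay on HCT-116 cells (Homo sapiens) for cytotoxicity, with a stated time of 3 days (a lower number here means a stronger inhibitor, a higher number a weaker inhibitor), three small compounds have readings so far. Compound 1 (`C=Cc1nc2ccccc2[se]1`) gives > 40000 nM as its reading, and this is a limit of the assay, not a number. Compound 2 (`C#Cc1ncccn1`) gives > 40000 nM as its reading, which is also a limit. Compound 3 (`C#Cc1nc2ccccc2n1C`) gives 19400 nM as its reading, and this one is a true number. Compound 1 therefore stands at the limit of > 40000 nM in this assay, at which 2 of the 3 values shown sit, and has no exact value to build on.

Compound 4 (`c1ccc2[se]cnc2c1`) keeps the core of compound 1 but has hydrogen in place of vinyl on an aromatic carbon. Going by the values given here, no measured pair shows what this change does. Compound 1 shows the limit > 40000 nM in this assay and so gives little to go on, and the step expected here is none beyond the usual scatter. The estimated change is a number no higher from compound 1 to compound 4 (the limit leaves the size open) and may well end in another limit. The expected value for compound 4 is 40000 nM with an estimated range from 20000 nM to 80000 nM in this test.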

Compound 4, half-maximal inhibitory concentration: > 40000 nM
Compound 4: no number, only a limit; the forecaster's own chance of this, stated with the estimate: 70%; the middle value lies on the limit itself.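

No step can be read from compound 1 to compound 4, because both readings are limits of the assay and not numbers: the limit of > 40000 nM in this assay, at which 3 of the 4 values shown sit. The compounds shown leave open whether hydrogen in place of vinyl on an aromatic carbon changes the reading at all.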